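The compounds below may be only part of what the source reports. "The series", "measured", "known", "first", "only" and "open" are said of these compounds alone.

Measured compounds in a functional assay on HTB-54 cells (Homo sapiens) for cytotoxicity, read by MTT assay, with a stated time of 72 h; on this read-out higher numbers stand for weaker inhibition of growth and lower numbers for stronger inhibition of growth:
- compound 1 `CCCCC[Se]c1nc(NCc2ccccc2)c2ccccc2n1` gives 37700 nM
- compound 2 `[SeH]c1nc(NCc2ccccc2)c2ccccc2n1` gives 31200 nM
- compound 3 `Nc1nc([SeH])nc2ccccc12` gives 40 nM

Compound 2 and compound 1 differ in one place, (pentyl in place of hydrogen on a selenium), and the step is a 1.2-fold higher number from compound 2 to compound 1 (0.08 log units; within the scatter). On this pair the pentyl on the selenium leaves the number essentially where it was.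

Compound 3 stands apart: in this assay compound 3 gives 40 nM, and its value lies far from both compound 2 and compound 1, beyond the scatter in each case. Among the compounds with values here, the difference between the core of compound 3 and the core of compound 2 is not broken down here, and no single-place step to compound 3 is counted.

Compound 4 `CCCCC[Se]c1nc(N)c2ccccc2n1` is not yet measured. It differs from compound 3 by pentyl in place of hydrogen on a selenium. Within the data shown here, this is the same change as the one from compound 2 to compound 1, made on the same kind of selenium with an aromatic carbon as its other neighbour, but now on the core of compound 3 rather than the core of compound 2.

For compound 4 the expected step is a 1.4-fold higher number from compound 3 to compound 4 (0.14 log units; within the scatter), which rests on the measured step of a 1.2-fold higher number from compound 2 to compound 1 (0.08 log units; within the scatter) being within the scatter. The core of compound 3 is different, so the transfer of that step is an assumption and the range is kept wide. Compound 4 is expected to give about 55 nM in this assay, estimated between 15 nM and 300 nM.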

Compound 4, concentration for 50% growth inhibition: 34600 nM
Estimate against measurement, compound 4: 630-fold (2.80 log units) below; the measured number lies above the stated range.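

In this assay, pentyl in place of hydrogen on a selenium does not carry from the core of compound 2 to the core of compound 3, so the step read on one core gives no guide to the other: the same change on two cores in this assay, a 1.2-fold higher number (0.08 log units; within the scatter) from compound 2 to compound 1 and an 870-fold higher number (2.94 log units; beyond the scatter) from compound 3 to compound 4, 720-fold (2.85 log units) apart, beyond the scatter of two such steps

On the core of compound 3 the change is large, an 870-fold higher number from compound 3 to compound 4 (2.94 log units; beyond the scatter), whereas hydrogen in place of benzyl on a nitrogen on an aromatic ring, with pentyl already on the selenium, gives a 1.1-fold lower number from compound 1 to compound 4 (0.04 log units; within the scatter), so with that pentyl present the benzyl makes no readable difference. This shows that the effect of the pentyl depends on the core in these two pairs, but it does not show why, and two pairs with a single chain on the selenium support no general rule for the series.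

On these data alone, it remains open whether methyl, ethyl or a longer chain on the selenium of the core of compound 3 would give a number as high as that of compound 4 or one closer to that of compound 3. Also open, as far as these compounds go, is whether methyl on the nitrogen, in place of benzyl, would leave the number of compound 3 where it stands.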